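The compounds below may be only part of what the source reports. "The series", "measured", "known", "first", "only" and "open" are said of these compounds alone.

Values in a functional assay (aorta) with Rattus norvegicus as the target (on this read-out lower numbers stand for stronger inhibition and higher numbers for weaker inhibition), so far

Compound 1 `CC1(C)Oc2ccc(C#N)cc2[C@@H](/N=C(\NC#N)Nc2cccc([N+](=O)[O-])c2)[C@@H]1O` gives 670 nM
Compound 2 `CC1(C)Oc2ccc(C#N)cc2[C@@H](/N=C(\NC#N)Nc2cccc(C(F)(F)F)c2)[C@@H]1O` gives 1600 nM
Compound 3 `CC1(C)Oc2ccc(C#N)cc2[C@@H](/N=C(\NC#N)Nc2cccc(C(=O)O)c2)[C@@H]1O` gives > 100000 nM (a limit of the assay)

Compound 3 stands at the limit of > 100000 nM in this assay, at which 1 of the 3 values shown sits, and so has a limit and no number. The next compound is compound 4 `CC1(C)Oc2ccc(C#N)cc2[C@@H](/N=C(\NC#N)Nc2ccc(Cl)c(Cl)c2)[C@@H]1O`, not yet measured in this assay. The change is 3,4-dichlorophenyl in place of 3-carboxyphenyl on an amine nitrogen. For the measured compounds named here, two measured steps bear most directly on it, both large and both ending at the carboxy compound: an at least 140-fold higher number from compound 1 to compound 3 (2.17 log units; beyond the scatter) and an at least 62-fold higher number from compound 2 to compound 3 (1.79 log units; beyond the scatter) are the main guide. The two compounds without carboxy differ only modestly (a 2.4-fold higher number from compound 1 to compound 2 (0.38 log units; beyond the scatter)), though that gap lies beyond the scatter. Compound 4 also has no carboxy group, as is true of compound 1 (670 nM) and compound 2 (1600 nM). Going by the values given here, no dichlorophenyl compound has been measured, so the expectation rests on these three compounds alone. The expected step is large and runs toward a lower number (an at least 110-fold lower number from compound 3 to compound 4 (2.04 log units; beyond the scatter)). The estimated value for compound 4 is 900 nM, with an expected range of 200 nM to 4000 nM.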

Compound 4, half-maximal inhibitory concentration: 4600 nM
Estimate against measurement, compound 4: 5.1-fold (0.71 log units) below, outside the stated range (above it).
By their numbers in this assay, from the lowest: compound 1; then compound 2; then compound 4. At a limit, above all of these: compound 3.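

In this assay, 3,4-dichlorophenyl on the amine nitrogen gives a measured value where 3-carboxyphenyl gave only a limit, with an at least 21-fold lower number from compound 3 to compound 4 (1.33 log units; beyond the scatter), so the large loss at compound 3 is not shared by this third aryl group without carboxy. That return is not complete, as a 2.9-fold higher number from compound 2 to compound 4 (0.46 log units; beyond the scatter) and a 6.9-fold higher number from compound 1 to compound 4 (0.84 log units; beyond the scatter), which places the 3,4-dichlorophenyl group highest among the three compounds with numbers, although both steps are modest and all three aryl groups remain far from the carboxy compound. Compound 3 remains a limit and not a number, so the true size of every step that ends or starts there stays unknown: the limit of > 100000 nM in this assay, at which 1 of the 4 values shown sits.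

The compounds shown leave open how 3-chlorophenyl and 4-chlorophenyl would read at this place, which would show whether one chlorine alone accounts for the gap between compound 4 and the two compounds carrying a single group. They also leave open whether the limit of compound 3 belongs to the carboxylic acid itself or would also appear with a methyl ester or a primary amide at the same place.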